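From 4-(dimethylamino)phenyl to 3,4-dimethoxyphenyl: Compound 4 Expected

The source may report more compounds than this note shows. Statements on the series, on what has been measured and on what is new or still open speak of the compounds shown alone.

Among the measured compounds shown here, compound 3 `CN(C)c1ccc(/C=C2\S/C(=N\c3csc(-c4ccc(Cl)cc4)c3)NC2=O)cc1` is the only member of the set with a numeric result: in a functional assay on HT-29 cells (Homo sapiens) for cytotoxicity, read by MTT assay, with a stated time of 72 h (on this read-out higher numbers stand for weaker inhibition and lower numbers for stronger inhibition), compound 3 gives 1500 nM. Compound 1 `Cc1ccc(-c2cc(/N=C3/NC(=O)CS3)cs2)cc1` gives only a limit in this assay, > 50000 nM. Compound 2 `COc1ccc(-c2cc(/N=C3/NC(=O)CS3)cs2)cc1` likewise gives a limit, > 50000 nM. For the measured compounds named here, the step that the two limits leave unreadable from compound 1 to compound 2 therefore cannot be read, and the sole evidence on the measured steps is the limit of > 50000 nM in this assay, at which 2 of the 3 values shown sit. Compound 4 `COc1ccc(/C=C2\S/C(=N\c3csc(-c4ccc(Cl)cc4)c3)NC2=O)cc1OC` differs from compound 3 by 3,4-dimethoxyphenyl in place of 4-(dimethylamino)phenyl on a double-bonded chain carbon bound to a double-bonded ring carbon. Going by the values given here, no measured step touches this change, and the expectation is of no shift beyond the scatter in either direction. Compound 4 is therefore estimated to give 2000 nM (600 nM to 8000 nM) in this assay. The expected step is a 1.3-fold higher number from compound 3 to compound 4 (0.12 log units; within the scatter).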

Compound 4, half-maximal inhibitory concentration: 10900 nM
Estimate against measurement, compound 4: 5.5-fold (0.74 log units) below, and the stated range ends below it.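

Among the compounds shown here, this is the first readable step in the set: in this assay, putting 3,4-dimethoxyphenyl in place of 4-(dimethylamino)phenyl on a double-bonded chain carbon bound to a double-bonded ring carbon gives a 7.3-fold higher number from compound 3 to compound 4 (0.86 log units; beyond the scatter). Inhibition at this position therefore depends on which aromatic group it carries, and this change weakens it. Nothing shown accounts for the shift.

On these data alone, whether an unsubstituted phenyl or a 4-morpholinophenyl would stay nearer compound 3 or compound 4 remains open. A single step cannot separate the loss of the dimethylamino group from the entry of the two methoxy groups.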